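Fluoromethyl for hydroxymethyl on the methylamino nucleoside

The compounds below may be only part of what the source reports. "The series", "measured", "known", "first", "only" and "open" are said of these compounds alone.

Measured compounds:
compound 1 `CNc1ccnc2c1ncn2[C@@H]1O[C@H](CO)[C@](O)(CO)[C@H]1O`: 11800 nM
compound 2 `Nc1ccnc2c1ncn2[C@@H]1O[C@H](CO)[C@](O)(CF)[C@H]1O`: > 100000 nM

In an ADME assay on Huh-7 cells (Homo sapiens) for cytotoxicity, read by WST assay, with a stated time of 3 days (on this read-out lower numbers stand for higher toxicity in this test and higher numbers for lower toxicity in this test), compound 1 gives 11800 nM. Among the values shown this is the only actual number; the other entry is a limit. In this assay compound 2 reaches only the limit of the test, > 100000 nM. That sets (the limit of > 100000 nM in this assay, at which 1 of the 2 values shown sits), the boundary the read-out cannot pass.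

Compound 3 `CNc1ccnc2c1ncn2[C@@H]1O[C@H](CO)[C@](O)(CF)[C@H]1O` is not yet measured in this assay. It differs from compound 1 by fluoro in place of hydroxy on a saturated chain carbon bound to a saturated ring carbon. Going by the values given here, no single-change step between measured compounds exists here, so the size of this change has no calibration within the set. Compound 2 shares the fluoromethyl of compound 3 but differs from compound 1 in two places, so its limit is only a loose pointer.

The expected step in this assay is a 4.2-fold higher number from compound 1 to compound 3 (0.63 log units; beyond the scatter), toward the less toxic side. Compound 3 is estimated at 50000 nM, within 15000 nM to 200000 nM, with a real chance that only a limit is reported.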

Compound 3, half-maximal cytotoxic concentration: > 100000 nM
Compound 3 was reported as a limit; the forecaster's own chance of this, stated with the estimate: 40%; middle value at least 2.0-fold (0.30 log units) from the limit.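

Fluoromethyl in place of hydroxymethyl gives an at least 8.4-fold higher number from compound 1 to compound 3 (0.92 log units; beyond the scatter) in this assay and is the only readable single-change step in the series, showing that this one exchange on the saturated chain carbon moves the number toward the less toxic side. On these data alone, compound 3 gives > 100000 nM as a limit of the test and not a number, so the full size of the step remains unknown. Compound 2 and compound 3, the two fluoromethyl compounds, now end at the same boundary: the limit of > 100000 nM in this assay, at which 2 of the 3 values shown sit.

As far as these compounds go, the step between compound 2 and compound 3 cannot be read, so the contribution of methyl on the aromatic-ring nitrogen stays unknown in this assay. Also open, from the compounds shown here alone, is whether a methoxy, an amine or a plain hydrogen in place of fluoro would shift the number as far.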